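The source may hold more compounds than are shown below. What is called first, only, known or untested is meant among the compounds shown, and "the series" means these compounds.

Compound 3 `O=C1C(=O)N(CCCn2cc(COc3cc(=O)oc4ccccc34)nn2)c2ccc(Cl)cc21` is the point of departure. Among the compounds with values here, in a functional assay on COLO 205 cells (Homo sapiens) for inhibition, read by sulforhodamine B assay, with a stated time of 48 h, tested at 50 uM (a higher number here means more inhibition of growth at the concentration tested, a lower number less inhibition of growth), compound 3 gives 67%, the second highest of the three numbers so far. Its nearest neighbour is compound 2 `O=C1C(=O)N(CCCn2cc(COc3cc(=O)oc4ccccc34)nn2)c2ccccc21`, which in this assay gives 75%; a number 8 percentage points lower from compound 2 to compound 3 (within the scatter). Furthest off is compound 1 `COc1ccc2c(c1)C(=O)C(=O)N2CCCn1cc(COc2cc(=O)oc3ccccc23)nn1`, which gives 48%; a number 19 percentage points higher from compound 1 to compound 3 (beyond the scatter), and a number 27 percentage points higher from compound 1 to compound 2 (beyond the scatter). Compound 4 `O=C1C(=O)N(CCCn2cc(COc3cc(=O)oc4ccccc34)nn2)c2ccc([N+](=O)[O-])cc21` is the next member, not yet measured. The change from compound 3 is this: nitro in place of chloro on an aromatic carbon. Within the data shown here, the steps that bear on it are the two that vary the group on this same aromatic carbon: chloro in place of hydrogen stayed within the scatter, whereas chloro in place of methoxy was a modest rise. Among the measured compounds shown here, no measured step puts a nitro group at this carbon, so nothing shows whether nitro behaves more like chloro or more like methoxy. The expectation is accordingly a step of no size beyond the scatter, a number 2 percentage points lower from compound 3 to compound 4 (within the scatter), with wide uncertainty either way. Compound 4 is estimated at 65%, with a range from 45% to 85%.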

Compound 4, percent growth inhibition at one concentration: 52%
Compound 4: the middle estimate sits 13 percentage points above what was measured; measured number inside the range.
By their numbers in this assay, from the lowest: compounds 1 and 4 (each within the scatter of the next); then compounds 3 and 2 (each within the scatter of the next).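

At this aromatic carbon in this assay, nitro falls with methoxy and not with chloro: the step of a number 4 percentage points higher from compound 1 to compound 4 (within the scatter) stays small, while the steps of a number 15 percentage points lower from compound 3 to compound 4 (beyond the scatter) and a number 23 percentage points lower from compound 2 to compound 4 (beyond the scatter) are both modest drops. The series now splits into two levels, with compounds 2 and 3 in the upper one and compounds 1 and 4 in the lower one, so the loss of growth inhibition at this carbon is no longer tied to methoxy alone. Among the four groups shown, only hydrogen and chloro hold the upper level.

No evidence here explains why nitro and methoxy land together. On these data alone, whether an amine, a carboxylic acid or a nitrile on this carbon would join the upper or the lower pair remains open.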